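A few compounds are considered here, and "the series" means these few. Any claim that something is new, unique, unknown or untested is made for them only; others in the source may bear on it.

In a functional assay on MDA-MB-231 cells (Homo sapiens) for antiproliferative activity, read by MTT assay, with a stated time of 72 h (on this read-out lower numbers stand for stronger inhibition and higher numbers for weaker inhibition), compound 1 `COc1cc(-c2nccn2CC(C)C)cc(OC)c1OC` gives > 100000 nM, which is a limit of the assay and not a number. Compound 2 `COc1ccc(-n2ccnc2-c2cc(OC)c(OC)c(OC)c2)cc1[N+](=O)[O-]` gives a measured value of 7500 nM. Compound 3 `COc1cc(-c2nccn2-c2ccc(F)cc2)cc(OC)c1OC` keeps the core of compound 1 but has 4-fluorophenyl in place of isobutyl on an aromatic nitrogen. Within the data shown here, no measured step isolates this change, so the expectation leans on compound 2 at 7500 nM, which shows that a measurable value is reachable. A large move toward stronger inhibition is expected in this assay, the estimated step of an at least 10-fold lower number from compound 1 to compound 3 (1.00 log units; beyond the scatter). For compound 3 the expected value is 10000 nM, with an estimated range from 2000 nM to 50000 nM.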

Compound 3, half-maximal inhibitory concentration: 38400 nM
Compound 3: the middle estimate sits 3.8-fold (0.58 log units) below what was measured, and the stated range covers the measured number.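

In this assay, 4-fluorophenyl in place of isobutyl on this aromatic nitrogen gives an at least 2.6-fold lower number from compound 1 to compound 3 (0.41 log units; beyond the scatter), so a change at this position alone can shift the read-out beyond the scatter. The value of compound 1 is a limit of the assay and not a number, and the true size of the step stays unknown because of that limit: the limit of > 100000 nM in this assay, at which 1 of the 3 values shown sits.

The compounds shown leave open whether the six-membered ring or its fluorine accounts for the step. A plain phenyl or a longer chain on this nitrogen would help separate the two.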